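The compounds below may be only part of what the source reports. "The series", "measured", "known", "first", "only" and "open" are said of these compounds alone.

In a functional assay on CHO-K1 cells for antagonist activity at adenosine receptor A1 (Homo sapiens), read by a beta-galactosidase reporter and cAMP accumulation, with stated times of 15 min and 6 h (a lower number here means a stronger inhibitor, a higher number a weaker inhibitor), compound 3 `N#Cc1cccc(-c2nc(N)c3cc(Cc4ccccc4Cl)sc3n2)c1` gives 24.8 nM. Compound 1 `Cc1csc(-c2nc(N)c3cc(Cc4ccccc4F)sc3n2)n1` gives 28.6 nM, a gap from compound 3 that lies within the scatter, while compound 2 `N#Cc1cccc(-c2nc(N)c3cc(Cc4ccccc4)sc3n2)c1` gives 222 nM; the measured step of a 9.0-fold lower number from compound 2 to compound 3 (0.95 log units; beyond the scatter) is beyond the scatter. Compound 4 `N#Cc1cccc(-c2nc(N)c3cc(Cc4ccccc4F)sc3n2)c1` differs from compound 3 in one place: fluoro in place of chloro on an aromatic carbon. Among the compounds with values here, no measured pair shows this exact swap, so only indirect guidance exists. Compound 1 carries the same 2-fluorobenzyl and in this assay sits within the scatter of compound 3, which suggests no large move. Compound 4 is therefore expected to come out near compound 3, with the estimated step of a 1.5-fold higher number from compound 3 to compound 4 (0.19 log units; within the scatter) likely inside the scatter. The estimate for compound 4 is 38 nM, with a range from 14 nM to 110 nM.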

Compound 4, inhibition constant: < 16 nM
Compound 4: no number, only a limit (the forecaster's own chance of this, stated with the estimate: 2%); at least 2.3-fold (0.37 log units) between middle value and limit.
By their numbers in this assay, from the lowest: compounds 3 and 1 (each within the scatter of the next); then compound 2. At a limit, below all of these: compound 4.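

The reading for compound 4 is a limit and not a number: the limit of < 16 nM in this assay, at which 1 of the 4 values shown sits. With the 3-cyanophenyl kept, fluoro in place of hydrogen gives an at least 13-fold lower number from compound 2 to compound 4 (1.14 log units; beyond the scatter), so chloro is not the only halogen at this place that outdoes hydrogen. Fluoro in place of chloro gives an at least 1.5-fold lower number from compound 3 to compound 4 (0.19 log units; that floor lies within the scatter), and 3-cyanophenyl in place of 4-methyl-1,3-thiazol-2-yl gives an at least 1.7-fold lower number from compound 1 to compound 4 (0.25 log units; that floor lies within the scatter), so neither floor shows a real gain.

From the compounds shown here alone, the true size of both of those steps stays open. So does how a bromo or a methoxy group on this aromatic carbon would compare.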